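The source may report more compounds than this note shows. Statements on the series, on what has been measured and on what is new or still open speak of the compounds shown alone.

Measured compounds in a functional assay on HeLa cells (Homo sapiens) for inhibition, read by MTT assay, with a stated time of 72 h; on this read-out lower numbers stand for stronger inhibition and higher numbers for weaker inhibition:
Compound 1 `COc1cc(OC)c(OC)cc1/C=C/C(=O)c1cc(Cl)ccc1O` reaches only the limit of this assay, > 150000 nM.
Compound 2 `COc1cc(OC)c(OC)cc1/C=C/C(=O)c1ccc(Cl)c([N+](=O)[O-])c1` gives 16500 nM.
Compound 3 `COc1cc(OC)c(-c2cc(=O)c3ccc(O)cc3o2)cc1OC` reaches only the limit of this assay, > 150000 nM.

Compound 1 therefore stands at a limit rather than at a measured number, a position shared with one other compound, as the limit of > 150000 nM in this assay, at which 2 of the 3 values shown sit, shows. Compound 2 alone gives a number inside the measured range. Compound 4 `COc1cc(OC)c(OC)cc1/C=C/C(=O)c1ccccc1` differs from compound 1 by phenyl in place of 5-chloro-2-hydroxyphenyl on a carbonyl carbon. Among the measured compounds shown here, no step between measured compounds is available to size this change. In this assay the step of an at least 2.5-fold lower number from compound 1 to compound 4 (0.39 log units; beyond the scatter) is expected, since any number for compound 4 would lie on the stronger side of the limit at which compound 1 sits. The estimate for compound 4 is 60000 nM, with a range from 15000 nM to 150000 nM.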

Compound 4, half-maximal inhibitory concentration: > 150000 nM
Compound 4: only a limit was reported; the forecaster's own chance of this, stated with the estimate: 40%; at least 2.5-fold (0.39 log units) between middle value and limit.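

In this assay compound 4 gives only a limit, > 150000 nM. Among the compounds shown here, compound 1 also sits at a limit, so no step between compound 1 and compound 4 can be read. Going by these compounds, whether phenyl or 5-chloro-2-hydroxyphenyl on the carbonyl carbon gives the lower number stays open.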